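The compounds below may be only part of what the source reports. "The series", "measured", "known", "first", "only" and "open" are said of these compounds alone.

Series notes. Compound 1 `CCC(C)C(NC(=O)n1nnc2ccccc21)C(=O)NC1CCCCC1` carries the shared core with a sec-butyl side chain and a cyclohexyl amide; in a functional assay on MIA PaCa-2 cells (Homo sapiens) for inhibition (on this read-out lower numbers stand for stronger inhibition and higher numbers for weaker inhibition), compound 1 gives 40200 nM. Compound 2 `CCC(C)C(NC(=O)n1nnc2ccccc21)C(=O)NCc1ccccc1` keeps that side chain with a benzyl amide. In this assay compound 2 reports > 100000 nM, a limit and not a number. Compound 3 `CC(C)C(NC(=O)n1nnc2ccccc21)C(=O)NC1CCCC1` pairs an isopropyl side chain with a cyclopentyl amide. In this assay compound 3 also reports > 100000 nM, again a limit and not a number. Compound 3 thus stands at the limit of > 100000 nM in this assay, at which 2 of the 3 values shown sit, so only a ceiling is known for it. For the measured compounds named here, the only measured step, an at least 2.4-fold higher number from compound 1 to compound 2 (0.39 log units; beyond the scatter), concerns the amide substituent, not the side chain. Compound 4 `CCC(C)C(NC(=O)n1nnc2ccccc21)C(=O)NC1CCCC1` differs from compound 3 by methyl in place of hydrogen on a saturated chain carbon, three bonds along the chain from an amide-type nitrogen and a carbonyl carbon, i.e. isopropyl to sec-butyl. Going by the values given here, no measured step touches this position, so the size cannot be read from the measured pairs; the only anchor is compound 1, which also carries sec-butyl and gives 40200 nM rather than a limit. Compound 4 is therefore expected to come out near 80000 nM, within 25000 nM to 250000 nM, with a real chance of a limit only. The expected step, an at least 1.2-fold lower number from compound 3 to compound 4 (0.09 log units; that floor lies within the scatter), is an estimate, not a measurement.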

Compound 4, half-maximal inhibitory concentration: >= 100000 nM
Compound 4: a limit, no number; the forecaster's own chance of this, stated with the estimate: 50%; middle value at least 1.2-fold (0.09 log units) from the limit.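

In this assay compound 4 is a limit and not a number, like compound 3 with the same cyclopentyl amide: the limit of >= 100000 nM in this assay, at which 1 of the 4 values shown sits. The steps from compound 3 and from compound 2 to compound 4 cannot be read, each joining two limits, so methyl in place of hydrogen at this position has no measured size. For the compounds shown here, with sec-butyl held, the change of amide gives an at least 2.4-fold higher number from compound 1 to compound 4 (0.39 log units; beyond the scatter), so among the sec-butyl compounds the only numerical reading so far goes with the cyclohexyl amide of compound 1, and sec-butyl alone does not bring a numerical reading.

Going by these compounds, whether the isopropyl to sec-butyl change has any effect stays open, with a cyclopentyl amide on both sides giving no number. Also open, on these data alone, are isopropyl with a cyclohexyl amide, and a longer chain or a carboxylic acid in place of sec-butyl.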